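Swapping a furan-bearing chain for tert-butyl on an adenine ester

The compounds below may be only part of what the source reports. "The series", "measured", "known", "first", "only" and "open" are said of these compounds alone.

Among the measured compounds shown here, compound 3 `Nc1ncnc2c1ncn2CC(O)C(=O)OCc1ccco1` is the one member of this small set to give a number rather than a limit in a functional assay on PRK cells (Oryctolagus cuniculus) for cytotoxicity (on this read-out lower numbers stand for higher toxicity in this test and higher numbers for lower toxicity in this test), where compound 3 gives 40 ug/mL. Compound 1 `COCCOC(=O)C(O)Cn1cnc2c(N)ncnc21` reaches only the limit of the test, giving > 400 ug/mL. Compound 2 `COC(=O)C(O)Cn1cnc2c(N)ncnc21` likewise stops at the limit, with > 400 ug/mL. The steps of an at least 10-fold lower number from compound 1 to compound 3 (1.00 log units; beyond the scatter) and an at least 10-fold lower number from compound 2 to compound 3 (1.00 log units; beyond the scatter) show that bringing in the furan-2-yl group on the saturated chain carbon bound to an oxygen next to a carbonyl group goes together with the only clear toxicity seen; the step that the two limits leave unreadable from compound 1 to compound 2 cannot be sized because of the limit of > 400 ug/mL in this assay, at which 2 of the 3 values shown sit.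

Compound 4 `CC(C)(C)OC(=O)C(O)Cn1cnc2c(N)ncnc21` differs from compound 3 by the change (tert-butyl in place of (furan-2-yl)methyl on an oxygen next to a carbonyl group). Since the furan-containing group leaves and an alkyl group without a ring enters, the two steps into compound 3 are the ones that bear on this move, and both were at least modest. An increase in this assay is therefore expected from compound 3 to compound 4, of roughly a 6.3-fold higher number from compound 3 to compound 4 (0.80 log units; beyond the scatter). Compound 4 is estimated at 250 ug/mL, within 80 ug/mL to 400 ug/mL, with a fair chance that only the limit is reported.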

Compound 4, minimum cytotoxic concentration: > 400 ug/mL
Compound 4 gave a limit, no number (the forecaster's own chance of this, stated with the estimate: 55%); at least 1.6-fold (0.20 log units) between middle value and limit.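

In this assay, tert-butyl in place of (furan-2-yl)methyl on an oxygen next to a carbonyl group gives an at least 10-fold higher number from compound 3 to compound 4 (1.00 log units; beyond the scatter), so this change can now be read directly at this oxygen. Tert-butyl joins methyl and 2-methoxyethyl at the limit, which leaves compound 3, the only one of the four with a ring in this group, as the only one to give a number. The steps to compound 4 from compound 1 and from compound 2 cannot be read, because both ends of each step sit at the same limit: the limit of > 400 ug/mL in this assay, at which 3 of the 4 values shown sit.

The compounds shown leave open whether the toxicity goes with the furan ring in particular or with any ring at this oxygen. A benzyl group there would separate these two readings, and a free carboxylic acid would show how the unesterified form behaves.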